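A few compounds are considered here, and "the series" means these few. Any claim that something is new, unique, unknown or untested is made for them only; others in the source may bear on it.

Compound 1 `O=C(O)CN1C(=O)/C(=C/c2nc3ccccc3n2Cc2ccc([N+](=O)[O-])cc2)SC1=S`: 7760 nM
Compound 2 `O=C(O)CN1C(=O)/C(=C/c2nc3ccccc3n2Cc2ccccc2)SC1=S`: 1820 nM
Compound 3 `O=C(O)CN1C(=O)/C(=C/c2nc3ccccc3n2Cc2ccc(Cl)cc2)SC1=S`: 5580 nM

All three values come from a functional assay on MDA-MB-231 cells (Homo sapiens) for cytotoxicity, read by MTT assay, with a stated time of 48 h; a higher number here means a weaker inhibitor, a lower number a stronger inhibitor. Compound 3 sits within the scatter of compound 1 and above compound 2 on these numbers. The next compound, compound 4 `O=C(O)CN1C(=O)/C(=C/c2nc3ccccc3n2Cc2ccc(F)c(F)c2)SC1=S`, has not yet been measured. It differs from compound 3 in a single place: 3,4-difluorophenyl in place of 4-chlorophenyl on a saturated chain carbon bound to an aromatic nitrogen. In words, 3,4-difluorophenyl stands in place of 4-chlorophenyl on a saturated chain carbon bound to an aromatic nitrogen.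

Within the data shown here, two measured steps bear on this change. Chloro in place of hydrogen gave a 3.1-fold higher number from compound 2 to compound 3 (0.49 log units; beyond the scatter), so adding a group to the bare ring made a modest difference. Chloro in place of nitro gave a 1.4-fold lower number from compound 1 to compound 3 (0.14 log units; within the scatter), so exchanging one group for another on the ring made no difference beyond the scatter. Compound 4 is also an exchange of groups, which makes the second step the closer guide. However, no measured compound carries fluorine, so the guide is only a loose one.

In this assay, no change beyond the scatter is expected, and the estimated step is a 1.2-fold lower number from compound 3 to compound 4 (0.09 log units; within the scatter). The estimate for compound 4 is 4500 nM, with an expected range from 1900 nM to 10000 nM.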

Compound 4, half-maximal inhibitory concentration: 3760 nM
For compound 4 the middle estimate is 1.2-fold (0.08 log units) above the measured one; low and high end bracket the measured number.
By their numbers in this assay, from the lowest: compound 2; then compounds 4, 3 and 1 (each within the scatter of the next, the first and the last beyond it).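

In this assay, the exchange at this position gives a 1.5-fold lower number from compound 3 to compound 4 (0.17 log units; within the scatter), so replacing 4-chlorophenyl with 3,4-difluorophenyl on the saturated chain carbon bound to an aromatic nitrogen brings no change that can be told from the scatter. The bare ring keeps the lowest number of the four, since 3,4-difluorophenyl in place of phenyl gives a 2.1-fold higher number from compound 2 to compound 4 (0.32 log units; beyond the scatter), and all three substituted rings, now including one that carries fluorine, therefore stand above compound 2. Against the nitro-bearing ring, the same group gives a 2.1-fold lower number from compound 1 to compound 4 (0.31 log units; beyond the scatter), a gap beyond the scatter that the chloro compound did not show, so the substituted rings do not all sit at one level, even though compound 3 lies within the scatter of both compound 1 and compound 4.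

Nothing available here gives a reason for this order among the rings. The compounds shown leave open how a 4-fluorophenyl or a ring bearing a methoxy group or an amine would compare with the bare phenyl, and what a longer chain in place of the saturated chain carbon would do.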